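A few compounds are considered here, and "the series" means these few. Any claim that something is new, unique, unknown or untested is made for them only; others in the source may bear on it.

Measured so far in a functional assay on the whole organism (strain Sprague-Dawley) for inhibition, with Rattus norvegicus as the target; on this read-out lower numbers stand for an effect already at smaller amounts and higher numbers for an effect only at larger amounts of compound:
compound 1 `O=C(O)c1cnc2c(F)cccc2c1`: 150 mg/kg
compound 2 `COc1ccc2ncc(-c3nn[nH]n3)cc2c1`: > 25 mg/kg
compound 3 `CC(C)Oc1cccc2c(=O)c(-c3nn[nH]n3)c[nH]c12`: 1.25 mg/kg

Among the compounds with values here, compound 2 stands only at a limit of this assay, not at a number; it is the one value sitting at the limit of > 25 mg/kg in this assay, at which 1 of the 3 values shown sits. Compound 1 and compound 3 each give a measured minimum effective dose, far apart from one another.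

Compound 4 `Fc1ccc2ncc(-c3nn[nH]n3)cc2c1` is not yet measured. It shares the core of compound 2 and differs from it only by fluoro in place of methoxy on an aromatic carbon. Within the data shown here, no measured pair in the set shows this change, so its size in this assay is open; with compound 2 known only as a limit, no step beyond the usual scatter is expected in either direction. Compound 4 is expected near 50 mg/kg, between 12 mg/kg and 200 mg/kg. The expected step is a step that the limit leaves unreadable from compound 2 to compound 4.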

Compound 4, minimum effective dose: 50 mg/kg
The estimate for compound 4 equals the measured number at the digits printed, and the stated range covers the measured number.
By their numbers in this assay, from the lowest: compound 3; then compound 4; then compound 1.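

No step from compound 2 to compound 4 can be read in this assay, as compound 2 stands only at a limit: the limit of > 25 mg/kg in this assay, at which 1 of the 4 values shown sits.

The compounds shown leave open the size of the change from methoxy to fluoro on the shared core.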